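Triazole-linked pyrazole carboxamides: benzyl substituent swap on a weaker core

A few compounds are considered here, and "the series" means these few. Any claim that something is new, unique, unknown or untested is made for them only; others in the source may bear on it.

Compound 1 `O=C(NCc1cn(Cc2ccc(Cl)cc2)nn1)c1cn(-c2ccccc2)nc1-c1ccc(F)cc1` gives 280 nM in a functional assay on MIA PaCa-2 cells (Homo sapiens) for antiproliferative activity, read by sulforhodamine B assay, with a stated time of 48 h; on this read-out lower numbers stand for stronger inhibition of growth and higher numbers for weaker inhibition of growth. Compound 2 `O=C(NCc1cn(Cc2ccc(C(F)(F)F)cc2)nn1)c1cn(-c2ccccc2)nc1-c1ccc(F)cc1` differs from it only by trifluoromethyl in place of chloro on an aromatic carbon and gives 760 nM, so that a 2.7-fold higher number from compound 1 to compound 2 (0.43 log units; beyond the scatter). Compound 3 `COc1ccc(-c2nn(-c3ccccc3)cc2C(=O)NCc2cn(Cc3ccc(Cl)cc3)nn2)cc1` carries a different core, set apart from that of compound 1 by methoxy in place of fluoro on an aromatic carbon; in this assay compound 3 gives 26300 nM, and a 94-fold higher number from compound 1 to compound 3 (1.97 log units; beyond the scatter). Compound 4 `COc1ccc(-c2nn(-c3ccccc3)cc2C(=O)NCc2cn(Cc3ccc(C(F)(F)F)cc3)nn2)cc1` has not yet been measured. It stands to compound 3 as compound 2 stands to compound 1: the change is trifluoromethyl in place of chloro on an aromatic carbon, with the same placement as before, so the same change is being repeated on the core of compound 3. For the measured compounds named here, with only one earlier instance of this change, the single measured step is the only guide. Compound 4 is therefore expected to show a step of about a 2.5-fold higher number from compound 3 to compound 4 (0.39 log units; beyond the scatter), because compound 1 to compound 2 gave a 2.7-fold higher number from compound 1 to compound 2 (0.43 log units; beyond the scatter). The expected value for compound 4 in this assay is 65000 nM, within an estimated range of 22000 nM to 160000 nM. Given how high the number for compound 3 already is, there is a fair chance that the assay returns only a limit for compound 4.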

Compound 4, concentration for 50% growth inhibition: > 100000 nM
Compound 4: only a limit was reported; the forecaster's own chance of this, stated with the estimate: 35%; at least 1.5-fold (0.18 log units) between middle value and limit.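

In this assay compound 4 gives > 100000 nM, which is a limit and not a number. Both changes point the same way on the second core as on the first: trifluoromethyl in place of chloro gives an at least 3.8-fold higher number from compound 3 to compound 4 (0.58 log units; beyond the scatter), and methoxy in place of fluoro gives an at least 130-fold higher number from compound 2 to compound 4 (2.11 log units; beyond the scatter). This shows that the direction of the trifluoromethyl change carries over between these two cores, but not that its size does: the same change on two cores in this assay, a 2.7-fold higher number (0.43 log units; beyond the scatter) from compound 1 to compound 2 and an at least 3.8-fold higher number (0.58 log units; beyond the scatter) from compound 3 to compound 4; the limit leaves it open whether they differ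

With only two cores shown, it remains open whether the same direction holds when an amine, a hydroxyl or a longer alkoxy chain stands in the place of fluoro and methoxy. From the compounds shown here alone, it also remains open how a nitrile or a carboxylic acid in the place of chloro and trifluoromethyl would compare on either core, and whether a core carrying methoxy can give a measurable step at all.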